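The source may hold more compounds than are shown below. What is called first, only, known or untested is meant among the compounds shown, and "the series" means these compounds.

Measured so far in a functional assay on HeLa cells (Homo sapiens) for inhibition, read by sulforhodamine B assay; a lower number here means a stronger inhibitor, a higher number a weaker inhibitor:
Compound 1 `COc1cccc(NC2=CC(=O)c3c(nc4n3[C@H]3OC[C@@H](O)[C@H]3OC4)C2=O)c1` gives > 8000 nM, which is a limit of the assay rather than a number.
Compound 2 `CCc1ccc(NC2=CC(=O)c3nc4n(c3C2=O)[C@H]2OC[C@@H](O)[C@H]2OC4)cc1` gives 3990 nM.
Compound 3 `O=C1C=C(NC2CCCC2)C(=O)c2c1nc1n2[C@H]2OC[C@@H](O)[C@H]2OC1` gives > 16000 nM, again a limit and not a number.

Compound 1 therefore stands at one of the two limits among the three values, namely (the limit of > 8000 nM in this assay, at which 1 of the 3 values shown sits); only compound 2 has a true number, and compound 3 sits at the other limit, (the limit of > 16000 nM in this assay, at which 1 of the 3 values shown sits).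

Compound 4 `O=C1C(N2CCCC2)=CC(=O)c2c1nc1n2[C@H]2OC[C@@H](O)[C@H]2OC1` has not been measured. It differs from compound 1 in a single place (pyrrolidin-1-yl in place of (3-methoxyphenyl)amino on a double-bonded ring carbon). A group built on a six-membered aromatic ring thus gives way to a five-membered non-aromatic ring with one hetero atom, attached directly to the double-bonded ring carbon.

For the measured compounds named here, one measured step bears on this: an at least 4.0-fold higher number from compound 2 to compound 3 (0.60 log units; beyond the scatter), where an aromatic ring on the amine nitrogen was likewise exchanged for a saturated ring and the number rose at least modestly. By that comparison, compound 4 is expected to be no stronger than compound 1 and probably weaker, so a step upward in this assay or none beyond the scatter is expected, a step that the limit leaves unreadable from compound 1 to compound 4. Compound 4 is thus estimated at about 20000 nM, within 8000 nM to 60000 nM, and is likely to be reported only as a limit.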

Compound 4, half-maximal inhibitory concentration: > 16000 nM
Compound 4: no number, only a limit (the forecaster's own chance of this, stated with the estimate: 85%); the middle value lies beyond the limit too.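

Compound 4 gives > 16000 nM, which is a limit and not a number. Compound 1 also stands at a limit, so no step can be read between the two compounds. The compounds shown leave open whether pyrrolidin-1-yl in place of (3-methoxyphenyl)amino changes the strength of inhibition at all, and by how much.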